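This account rests on a few compounds, and the source may have more. Where it says the series, first, only, none or still open, it means among the compounds named here.

Of the compounds shown here, three sharing one core have been tested in a functional assay on MCF7 cells (Homo sapiens) for inhibition, read by sulforhodamine B assay, with a stated time of 48 h; a higher number here means a weaker inhibitor of growth, a lower number a stronger inhibitor of growth. Compound 1 `COc1ccc(/C=C/C2(C)C=CC(=O)O2)c(OC)c1OC` gives 110000 nM in this assay. Compound 2 `COc1c(O)ccc(/C=C/C2(C)C=CC(=O)O2)c1OC` gives 45300 nM in this assay. Compound 3 `CC1(/C=C/c2ccc(O)cc2)C=CC(=O)O1` gives 69100 nM in this assay; this value lies within the usual scatter of that of compound 2 and also of that of compound 1, so no order among these three is claimed. One single change has been measured: a 2.4-fold higher number from compound 2 to compound 1 (0.39 log units; beyond the scatter), the change being (methyl in place of hydrogen on an oxygen on an aromatic ring). The difference between the core of compound 3 and the core of compound 2 is not broken down here.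

Compound 4 `COc1ccc(/C=C/C2(C)C=CC(=O)O2)cc1` has not yet been measured. It stands to compound 3 as compound 1 stands to compound 2: methyl in place of hydrogen on an oxygen on an aromatic ring. The description of the place is the same in both pairs, so this is the same change made a second time; across all the compounds shown it occurs twice. The account therefore expects the step from compound 3 to compound 4 to be of the size a 2.2-fold higher number from compound 3 to compound 4 (0.34 log units; beyond the scatter) in this assay, because the same change measured from compound 2 to compound 1 gave a 2.4-fold higher number from compound 2 to compound 1 (0.39 log units; beyond the scatter). For the measured compounds named here, on that basis compound 4 is expected to give about 150000 nM in this assay, with a likely range from 60000 nM to 350000 nM, a range kept wide since only one measured step supports it.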

Compound 4, concentration for total growth inhibition: 183000 nM
For compound 4 the middle estimate is 1.2-fold (0.09 log units) below the measured one; low and high end bracket the measured number.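

In this assay the change from hydroxy to methoxy again gives a weaker inhibitor of growth, with a 2.6-fold higher number from compound 3 to compound 4 (0.42 log units; beyond the scatter), so the step carries over to a second core at much the same size: the same change on two cores in this assay, a 2.4-fold higher number (0.39 log units; beyond the scatter) from compound 2 to compound 1 and a 2.6-fold higher number (0.42 log units; beyond the scatter) from compound 3 to compound 4, 1.1-fold (0.04 log units) apart, within the scatter of two such steps. Within these two pairs, the change therefore behaves as one transferable step on the core of compound 2 and the core of compound 3, and no pair among the compounds shown goes against it. For the compounds shown here, this rests on only two pairs in a single assay, however, and it shows neither why the number rises nor whether the step would hold on any further core.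

The compounds shown leave open what would happen if that oxygen carried something other than hydrogen or methyl, such as an ethyl group, a longer chain or an acetyl group, or if an amine or a carboxylic acid stood in place of the hydroxy group. They also leave open how each of the other methoxy groups that separate the core of compound 2 from the core of compound 3 contributes on its own, as that difference is not broken down into single steps.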